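A few compounds are considered here, and "the series" means these few. Any claim that something is new, unique, unknown or untested is made for them only; others in the source may bear on it.

Measured compounds:
Compound 1 `CCOc1cc(C(C)(C)C)ccc1C/N=C(\S)NCc1ccc(NS(C)(=O)=O)cc1` gives 1100 nM in a functional assay for inhibition of Vanilloid receptor (Rattus norvegicus); a lower number here means a stronger inhibitor, a higher number a weaker inhibitor.
Compound 2 `CCCCOc1cc(C(C)(C)C)ccc1C/N=C(\S)NCc1ccc(NS(C)(=O)=O)cc1` gives 60 nM in this assay.

Compound 1 stands highest of the two numbers; its nearest neighbour is compound 2, reached by an 18-fold lower number from compound 1 to compound 2 (1.26 log units; beyond the scatter). Compound 3 `CC(C)(C)COc1cc(C(C)(C)C)ccc1C/N=C(\S)NCc1ccc(NS(C)(=O)=O)cc1` differs from compound 1 by tert-butyl in place of methyl on a saturated chain carbon bound to an oxygen on an aromatic ring. Among the measured compounds shown here, the only measured step that bears on it, from compound 1 to compound 2, also lengthened the alkoxy chain and was large; the branched chain of compound 3 grows the chain in a different way, so a smaller lowering is expected. Compound 3 is estimated at 180 nM (range 50 nM to 600 nM), an expected 6.1-fold lower number from compound 1 to compound 3 (0.79 log units; beyond the scatter).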

Compound 3, half-maximal inhibitory concentration: 60 nM
Compound 3: middle estimate off by 3.0-fold (0.48 log units), on the high side, within the range that was stated.
By their numbers in this assay, from the lowest: compounds 2 and 3 (each within the scatter of the next); then compound 1.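

In this assay, the neopentyloxy chain does as much as the straight butoxy chain of compound 2: the change gives an 18-fold lower number from compound 1 to compound 3 (1.26 log units; beyond the scatter), and the comparison of the two chains gives no change at the digits printed from compound 2 to compound 3 (within the scatter). At this position, then, the large step away from the ethoxy group of compound 1 does not depend on the chain being unbranched. No evidence is at hand to explain this. Still open, from the compounds shown here alone, is whether a longer chain such as hexyloxy, or a cyclohexylmethoxy group, would stay at this level, and whether a chain ending in an amine or a carboxylic acid would keep it.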